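Amide Replacement on a Bis-sulfonyl Piperidine Scaffold

The source may hold more compounds than are shown below. What is called first, only, known or untested is meant among the compounds shown, and "the series" means these compounds.

Three compounds have been measured in a functional assay on MIA PaCa-2 cells (Homo sapiens) for inhibition, read by MTT assay, with a stated time of 7 days; on this read-out higher numbers stand for weaker inhibition and lower numbers for stronger inhibition:

Compound 1, `CCN(CC)S(=O)(=O)c1ccc(S(=O)(=O)N2CCC[C@@H](C(=O)N(C)C(C)C)C2)cc1`, gives 6200 nM.
Compound 2, `CCOC(=O)[C@@H]1CCCN(S(=O)(=O)c2ccc(S(=O)(=O)N(CC)CC)c(F)c2)C1`, gives 900 nM.
Compound 3, `CCOC(=O)[C@@H]1CCCN(S(=O)(=O)c2ccc(S(=O)(=O)N3CCCCC3)cc2)C1`, gives 2900 nM.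

Compound 1 stands as the weakest of the three: compound 3 lies nearest to it and compound 2 furthest, and both of these gaps fall beyond the usual scatter. Among the compounds with values here, none of these three compounds differs from another in only one place, so no single-point step is available from the measured set.

The next compound, compound 4, `CCN(CC)S(=O)(=O)c1ccc(S(=O)(=O)N2CCC[C@@H](C(=O)NC3CN(C(=O)NC(C)(C)C)C3)C2)cc1`, is derived from compound 1 by one change: (1-((tert-butyl)carbamoyl)azetidin-3-yl)amino in place of isopropyl(methyl)amino on a carbonyl carbon. Within the data shown here, nothing among the measured compounds tells how such a change at the carbonyl carbon plays out in this assay, so the expectation rests on the structural change alone and is held loosely. A modest step toward a lower number from compound 1 to compound 4 is expected, a 1.8-fold lower number from compound 1 to compound 4 (0.25 log units; within the scatter), close to the edge of the scatter. Compound 4 is accordingly estimated at 3500 nM, with a range from 900 nM to 14000 nM.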

Compound 4, half-maximal inhibitory concentration: 3400 nM
For compound 4 the middle estimate is 1.0-fold (0.01 log units) above the measured one, and the stated range covers the measured number.
By their numbers in this assay, from the lowest: compound 2; then compounds 3, 4 and 1 (each within the scatter of the next, the first and the last beyond it).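

At the carbonyl carbon, (1-((tert-butyl)carbamoyl)azetidin-3-yl)amino in place of isopropyl(methyl)amino gives a 1.8-fold lower number from compound 1 to compound 4 (0.26 log units; within the scatter) in this assay. Within the data shown here, this is the first single-place step in the set, and it shows that at this position a group of 12 heavy atoms, with a four-membered ring and 2 hydrogen-bond donors, can replace one of 5 heavy atoms with no ring and no donors without a step beyond the scatter. No measurement available here bears on the reason for this result.

The compounds shown leave open what the four-membered ring and the (tert-butyl)carbamoyl part each contribute on their own. They also leave open how a carboxylic acid, a primary amide or a morpholine amide would read at the same carbonyl carbon.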